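The source may report more compounds than this note shows. Statements on the series, on what has been measured and on what is new or still open speak of the compounds shown alone.

In a functional assay on KB cells (Homo sapiens) for antiproliferative activity, read by sulforhodamine B assay, with a stated time of 3 days (on this read-out higher numbers stand for an effect only at larger amounts of compound and lower numbers for an effect already at smaller amounts), compound 1 (`CCC1=C(O)c2c(oc(-c3ccccc3)cc2=O)C(CC)(CC)C1=O`) gives > 236 uM, which is a limit of the assay and not a number. Compound 2 (`CCC1=C(O)c2c(oc(-c3ccc(CC)cc3)cc2=O)C(CC)(CC)C1=O`), with ethyl in place of hydrogen on an aromatic carbon, gives 21.9 uM. Among the compounds with values here, this is the only measured step, an at least 10-fold lower number from compound 1 to compound 2 (1.03 log units; beyond the scatter), and it is large and beyond the scatter.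

Compound 3 (`CCC1=C(O)c2c(oc(-c3cccc(OC(F)(F)F)c3)cc2=O)C(CC)(CC)C1=O`) is unmeasured and changes compound 1 in a comparable way, with trifluoromethoxy in place of hydrogen on an aromatic carbon, meta to a large group: trifluoromethoxy in place of hydrogen on an aromatic carbon. Within the data shown here, the step to compound 2 is the only guide here, and it rests on one pair with a different group at its point of change, so it carries over only in part. Even so, its size, an at least 10-fold lower number from compound 1 to compound 2 (1.03 log units; beyond the scatter), points to a large step in this assay toward a lower number, though probably not one beyond it. The expected step is an at least 5.9-fold lower number from compound 1 to compound 3 (0.77 log units; beyond the scatter). For compound 3 the estimated value is 40 uM, with an expected range of 12 uM to 200 uM.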

Compound 3, concentration for half-maximal effect: > 47.4 uM
Compound 3 was reported as a limit; the forecaster's own chance of this, stated with the estimate: 25%; middle value at least 1.1-fold (0.07 log units) from the limit.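

In this assay compound 3 gives > 47.4 uM, a limit of the assay and not a number. Compound 1 also stands only as a limit, so no new step can be read between compound 1 and compound 3. The compounds shown leave open whether trifluoromethoxy in place of hydrogen on an aromatic carbon changes the number at all.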